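Replacing 4-Cyanophenyl with 2-Fluorophenyl in Compound 4

The source may hold more compounds than are shown below. What is called first, only, known or untested is meant among the compounds shown, and "the series" means these compounds.

Of the compounds shown here, three sharing one core have been tested in a functional assay on PC-12 cells (Rattus norvegicus) for cytotoxicity, read by MTT assay, with stated times of 2 h and 24 h, tested at 5 uM; on this read-out lower numbers stand for a weaker effect and higher numbers for a stronger effect at the one concentration tested. Compound 1 `Cc1ccc(-n2nc(-c3ccc(C(F)(F)F)cc3O)nc2-c2ccccc2O)cc1` gives 94.1%. Compound 2 `COc1ccc(-n2nc(-c3ccc(C(F)(F)F)cc3O)nc2-c2ccccc2O)cc1`, which carries a methoxy in place of the methyl on an aromatic carbon, gives 86.6%, and compound 3 `N#Cc1ccc(-n2nc(-c3ccc(C(F)(F)F)cc3O)nc2-c2ccccc2O)cc1`, which carries a cyano at that carbon, gives 86.8%. The three numbers lie close together: a number 7.5 percentage points lower from compound 1 to compound 2 (within the scatter), a number 7.3 percentage points lower from compound 1 to compound 3 (within the scatter), and a number 0.2 percentage points higher from compound 2 to compound 3 (within the scatter). Compound 3 thus stands second highest of the three, with compound 2 nearest and compound 1 furthest, yet none of these gaps exceeds the usual scatter, so the three cannot truly be ranked.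

Compound 4 `Oc1cc(C(F)(F)F)ccc1-c1nc(-c2ccccc2O)n(-c2ccccc2F)n1` has not yet been measured in this assay. It differs from compound 3 in one place: 2-fluorophenyl in place of 4-cyanophenyl on an aromatic nitrogen. Within the data shown here, every measured step so far altered only the group on that aromatic carbon, and each stayed within the scatter. Compound 4 exchanges the whole 4-cyanophenyl for 2-fluorophenyl, a kind of change not yet tried here, but nothing seen gives a reason to expect a move beyond the scatter. Compound 4 is therefore estimated at 88%, within 76% to 96%. That estimate means an expected a number 1.2 percentage points higher from compound 3 to compound 4 (within the scatter).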

Compound 4, a percentage reported as activity, at one concentration (the size of the read-out at that concentration, not a potency): 86.6%
Estimate against measurement, compound 4: 1.4 percentage points above; the range from low to high includes it.
By their numbers in this assay, from the lowest: compounds 2, 4, 3 and 1 (each within the scatter of the next).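

The earlier compounds shown here carried only 4-methylphenyl, 4-methoxyphenyl or 4-cyanophenyl on the aromatic nitrogen, so they tested a small group at one spot on that phenyl ring while the rest of the ring stayed in place. Compound 4 carries 2-fluorophenyl there instead, and in this assay this exchange gives a number 0.2 percentage points lower from compound 3 to compound 4 (within the scatter) and no change at the digits printed from compound 2 to compound 4 (within the scatter) and a number 7.5 percentage points lower from compound 1 to compound 4 (within the scatter) in the comparisons with the three earlier groups. The four compounds therefore cannot be told apart on this read-out, even with the whole group on this nitrogen exchanged, and no other measurement is available here to explain that result.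

From the compounds shown here alone, a reading at one concentration gives the size of the effect at that concentration only, so whether these four compounds would show a stronger or weaker effect at other concentrations remains open. Also open, going by these compounds, is whether something other than a substituted phenyl on this nitrogen, such as a longer alkyl chain, or a phenyl bearing an amine or a carboxylic acid, would move the number beyond the scatter.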